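Removing the Ring Methyl: Cytotoxicity Expectation for Compound 3

This account rests on a few compounds, and the source may have more. Where it says the series, first, only, none or still open, it means among the compounds named here.

Compound 1 `Cn1c(Cc2ccccc2C(F)(F)F)nc(C(=O)NCc2ccccc2)c(O)c1=O`: > 100000 nM
Compound 2 `CC(NC(=O)c1nc(Cc2ccccc2C(F)(F)F)n(C)c(=O)c1O)c1ccccc1`: > 100000 nM

In an ADME assay on HepG2 cells (Homo sapiens) for cytotoxicity, in the presence of a further agent that is not named here (on this read-out higher numbers stand for weaker inhibition and lower numbers for stronger inhibition), compound 1 gives > 100000 nM, which is a limit of the assay rather than a number. Compound 2 likewise gives > 100000 nM, again a limit. The step that the two limits leave unreadable from compound 1 to compound 2 therefore cannot be read, and it concerns a change at a different place from the one considered here. Compound 3 `O=C(NCc1ccccc1)c1nc(Cc2ccccc2C(F)(F)F)[nH]c(=O)c1O` has not yet been measured; it differs from compound 1 by hydrogen in place of methyl on an aromatic nitrogen. Among the compounds with values here, no measured step touches this position. Both measured compounds give only (the limit of > 100000 nM in this assay, at which 2 of the 2 values shown sit), so nothing shows that a change to the shared core moves the read-out into the measurable range. Compound 3 is therefore expected to give 100000 nM, within 30000 nM to 300000 nM, most likely once more only as a limit. The step of a number no higher from compound 1 to compound 3 (the limit leaves the size open) is thus expected to stay within the scatter.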

Compound 3, half-maximal inhibitory concentration: > 100000 nM
Compound 3: a limit, no number; the forecaster's own chance of this, stated with the estimate: 85%; the middle value sits exactly at the limit.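

In this assay, compound 1 and compound 3 both sit at an assay limit rather than at a number, so no step between them can be read: the limit of > 100000 nM in this assay, at which 3 of the 3 values shown sit.

The compounds shown leave open whether hydrogen in place of methyl on the aromatic nitrogen changes cytotoxicity at all.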